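Swapping Bromo for Chloro on the Benzyl Ring

A few compounds are considered here, and "the series" means these few. Any claim that something is new, unique, unknown or untested is made for them only; others in the source may bear on it.

Four compounds share one core and differ only in a single halogen on a six-membered aromatic ring of carbon only. Compound 1 `Brc1cccc(COc2nc3ccccc3s2)c1` carries bromo, compound 2 `Clc1cccc(COc2nc3ccccc3s2)c1` carries chloro in its place, and the two were measured in a functional assay on the whole organism with Mus musculus as the target, in the writhing test, at a dose of 100 mg/kg by the intraperitoneal route; a higher number here means more inhibition at the dose given (going by the name of the read-out), a lower number less inhibition. In this assay compound 1 gives 51.9% and compound 2 gives 51.9%, so the change chloro in place of bromo on an aromatic carbon made a step of no change at the digits printed from compound 1 to compound 2 (within the scatter). Compound 3 `Brc1ccc(COc2nc3ccccc3s2)cc1` is built from the same atoms as compound 1 joined differently; the difference between the two cores is not broken down here. In this assay compound 3 gives 51.9%, level with compound 1 and compound 2 within the scatter.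

Compound 4 `Clc1ccc(COc2nc3ccccc3s2)cc1` has not been measured. It differs from compound 3 by chloro in place of bromo on an aromatic carbon. Among the measured compounds shown here, this is the same kind of change as the one from compound 1 to compound 2, but in compound 3 the halogen sits para to a large group, whereas in compound 1 it sits meta to a large group. The step is expected to be a number 0.1 percentage points higher from compound 3 to compound 4 (within the scatter), because no change at the digits printed from compound 1 to compound 2 (within the scatter) showed that this halogen swap left the read-out unchanged. Compound 4 is therefore estimated at 52% in this assay, most likely between 40% and 63%.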

Compound 4, a percentage reported as inhibition, in the whole organism at one dose (the size of the read-out at that dose, not a potency): 51.9%
Compound 4: the middle estimate sits 0.1 percentage points above what was measured; the measured number falls inside the stated range.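

In this assay, putting chloro in place of bromo on an aromatic carbon gave no change at the digits printed from compound 3 to compound 4 (within the scatter), and this step matches the earlier one made on the other core: the same change on two cores in this assay, no change at the digits printed (within the scatter) from compound 1 to compound 2 and no change at the digits printed (within the scatter) from compound 3 to compound 4, 0 percentage points apart, within the scatter of two such steps

Within this assay, then, the swap carries across the two cores shown, whether the halogen sits as in compound 1 or para to a large group as in compound 3. This does not show that bromo and chloro are interchangeable in general: the read-out gives the size of the effect at one dose rather than a potency, and two cores are a small sample, so nothing here speaks to other doses, other tests or further cores.

All four compounds carry bromo or chloro on the six-membered aromatic ring and sit level with one another, which leaves open whether the read-out would shift at all with a different kind of group at that place, such as a methoxy group, an amine or a carboxylic acid. On these data alone, it also remains open how a ring with no halogen, or a longer chain in place of the short link to the shared core, would compare.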